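The compounds below may be only part of what the source reports. "The series", "measured", "known", "first", "only" and "open" are said of these compounds alone.

Compound 2 `C/C=C/C=C/C(=O)N[C@H](C(=O)NCCCCCCCCCCCCCCCCCC)[C@@H](C)O` is one of two measured compounds, and the other is compound 1 `CCCCCCCCCCCCCCCCCCNC(=O)[C@@H](NC(=O)c1cc2ccccc2n1C)[C@@H](C)O`. Within the data shown here, in a functional assay on HepG2 cells (Homo sapiens) for cytotoxicity, read by MTT assay, with a stated time of 48 h (on this read-out lower numbers stand for stronger inhibition and higher numbers for weaker inhibition), compound 2 gives 284000 nM, the only true number among the values shown. In this assay compound 1 reaches only a limit of the assay, > 200000 nM. Because of the limit of > 200000 nM in this assay, at which 1 of the 2 values shown sits, the step that the limit leaves unreadable from compound 1 to compound 2 cannot be read in size; both compounds show weak inhibition of the cells.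

Compound 3 `CCCCCCCCCCCCCCCCCCNC(=O)[C@@H](NS(=O)(=O)c1cccs1)[C@@H](C)O` differs from compound 2 in one place: (thiophen-2-yl)sulfonyl in place of (penta-1,3-dien-1-yl)carbonyl on an amine nitrogen. Among the measured compounds shown here, no measured step bears directly on this exchange, since the only step available, from compound 1 to compound 2, sits at a limit and is unreadable. With both measured compounds weak, the expectation for compound 3 is that it also stays weak, with no step beyond the scatter, so the estimated step of a 1.1-fold lower number from compound 2 to compound 3 (0.06 log units; within the scatter) is small. In this assay compound 3 is therefore estimated at 250000 nM, with a likely range from 80000 nM to 600000 nM, and a real chance that only a limit will be reported.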

Compound 3, half-maximal inhibitory concentration: > 200000 nM
Compound 3 gave a limit, no number; the forecaster's own chance of this, stated with the estimate: 55%; the middle value is on the limit's open side.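

In this assay compound 3 gives > 200000 nM as a limit and not a number. Among these compounds, no step among compound 1, compound 2 and compound 3 can be read in size, because of this: the limit of > 200000 nM in this assay, at which 2 of the 3 values shown sit. The compounds shown leave open whether (thiophen-2-yl)sulfonyl on the amine nitrogen changes the read-out at all.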